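Extending the Isoxazole Substituent in Acetylated Nucleoside Analogues

This account rests on a few compounds, and the source may have more. Where it says the series, first, only, none or still open, it means among the compounds named here.

Measured compounds:
compound 1, `CCCc1cc(-c2cn([C@H]3C[C@H](OC(C)=O)[C@@H](COC(C)=O)O3)c(=O)[nH]c2=O)on1`, 102%
compound 2, `CCCCCc1cc(-c2cn([C@H]3C[C@H](OC(C)=O)[C@@H](COC(C)=O)O3)c(=O)[nH]c2=O)on1`, 91.5%

In a functional assay on MDA-MB-231 cells (Homo sapiens) for cytotoxicity, read by sulforhodamine B assay, tested at 10 uM (a lower number here means less inhibition, a higher number more inhibition at the concentration tested (going by the name of the read-out)), compound 1 gives 102%, the highest of the two numbers; its nearest neighbour is compound 2, and the step of a number 10.5 percentage points lower from compound 1 to compound 2 (beyond the scatter). The unmeasured compound 3, `CCc1ccc(-c2cc(-c3cn([C@H]4C[C@H](OC(C)=O)[C@@H](COC(C)=O)O4)c(=O)[nH]c3=O)on2)cc1`, differs from compound 1 in one place: 4-ethylphenyl in place of propyl on an aromatic carbon. Among the measured compounds shown here, the only measured step that bears on this change is the growth of the same substituent from compound 1 to compound 2, which lowered inhibition modestly. Compound 3 enlarges that substituent further and gives it a ring, so a similar or somewhat larger loss is expected, while both measured numbers stand high in this assay. Compound 3 is therefore expected to give 88% in this assay, within 65% to 104%, a step of a number 14 percentage points lower from compound 1 to compound 3 (beyond the scatter).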

Compound 3, a percentage reported as inhibition, at one concentration (the size of the read-out at that concentration, not a potency): 97.4%
Estimate against measurement, compound 3: 9.4 percentage points below; the range from low to high includes it.
By their numbers in this assay, from the lowest: compounds 2, 3 and 1 (each within the scatter of the next, the first and the last beyond it).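

In this assay, 4-ethylphenyl in place of propyl gives a number 4.6 percentage points lower from compound 1 to compound 3 (within the scatter), so this aromatic carbon next to the ring nitrogen takes a six-membered aromatic ring of carbon only without a step beyond the scatter. Set against the longer chain, the same group gives a number 5.9 percentage points higher from compound 2 to compound 3 (within the scatter). Compound 3 thus lies within the scatter of both chain compounds, although those two are beyond it from each other, so the modest step seen on going from propyl to pentyl does not extend to this larger group. Nothing available accounts for this result.

The compounds shown leave open how an amine or a carboxylic acid on the phenyl ring would fare at this position. They also leave open what a methyl group would give here, and what free hydroxyl groups would give in place of the two acetates.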